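Compound 1 to compound 4: bromo in place of methoxy

The compounds below may be only part of what the source reports. "The series", "measured", "known", "first", "only" and "open" are said of these compounds alone.

In a functional assay on SK-MEL-147 cells (Homo sapiens) for cytotoxicity, read by MTT assay, with a stated time of 24 h (on this read-out lower numbers stand for an effect already at smaller amounts and higher numbers for an effect only at larger amounts of compound), compound 1 `CCOC(=O)c1cc([Se]Cc2ccccc2)c2cc(OC)ccc2n1` gives 40700 nM. Compound 2 `CCOC(=O)c1cc([Se]c2ccccc2)c2cc(OC)ccc2n1` gives 33000 nM. The comparison is a 1.2-fold lower number from compound 1 to compound 2 (0.09 log units; within the scatter), so phenyl in place of benzyl on a selenium leaves these two compounds within the scatter of each other.

Compound 3 `CCOC(=O)c1cc(C#CCCO)c2cc(OC)ccc2n1` reaches only a limit of the assay, > 150000 nM. The two steps to it are an at least 3.6-fold higher number from compound 1 to compound 3 (0.56 log units; beyond the scatter) and an at least 4.5-fold higher number from compound 2 to compound 3 (0.65 log units; beyond the scatter). Among the measured compounds shown here, compound 1 therefore sits within the scatter of compound 2, and its number is the only other measured value in this assay.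

Compound 4 `CCOC(=O)c1cc([Se]Cc2ccccc2)c2cc(Br)ccc2n1` keeps the benzyl on selenium and differs from compound 1 as follows: bromo in place of methoxy on an aromatic carbon. For the measured compounds named here, compounds 1, 2 and 3 all carry the methoxy, so none of the measured steps touches this place. Those steps bear on it only indirectly, as a measure of how far this series moves in this assay when the other substituent is changed.

With no direct guide, no step beyond the scatter is expected, in either direction. The expected step is a 1.2-fold lower number from compound 1 to compound 4 (0.09 log units; within the scatter). For compound 4 the estimated value is 33000 nM, with an expected range of 12000 nM to 80000 nM.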

Compound 4, half-maximal effective concentration: 31200 nM
The estimate for compound 4 lay 1.1-fold (0.02 log units) above the measured number, and the stated range covers the measured number.
By their numbers in this assay, from the lowest: compounds 4, 2 and 1 (each within the scatter of the next). At a limit, above all of these: compound 3.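

In this assay, bromo in place of methoxy on this aromatic carbon gives a 1.3-fold lower number from compound 1 to compound 4 (0.12 log units; within the scatter). Among the compounds shown here, this is the first direct reading at this place, since compound 1, compound 2 and compound 3 all carry the methoxy. With the benzyl on selenium held fixed, the exchange of a methoxy, which counts one hydrogen-bond acceptor, for a bromo, which counts none, stays within the usual scatter, so in this pair the methoxy is not needed for the effect seen with compound 1, and no measurement shown gives a cause for this outcome.

Open, from the compounds shown here alone, is whether the same exchange also stays within the scatter with phenyl on selenium, as in compound 2, or with the chain of compound 3, since this single pair carries the whole reading at this place. Also open, going by these compounds, is what a group such as an amine, a carboxylic acid or a trifluoromethyl would do on this aromatic carbon, and whether a group at this place can move the number beyond the scatter in this assay at all.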